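A few compounds are considered here, and "the series" means these few. Any claim that something is new, unique, unknown or untested is made for them only; others in the source may bear on it.

In a functional assay on SW1573 cells (Homo sapiens) for antiproliferative activity, read by sulforhodamine B assay, with a stated time of 48 h (on this read-out lower numbers stand for stronger inhibition of growth and higher numbers for weaker inhibition of growth), compound 1 `O=[N+]([O-])c1ccc(-c2nc(CO[C@@H]3O[C@H](CO)[C@H]4OC5(CCCC5)O[C@@H]34)no2)cc1` gives 27000 nM and compound 2 `O=[N+]([O-])c1ccc(-c2nc(CO[C@@H]3O[C@H](CSc4ncn[nH]4)[C@H]4OC5(CCCC5)O[C@@H]34)no2)cc1` gives 15000 nM; compound 2 holds the lower of the two numbers shown, yet a 1.8-fold lower number from compound 1 to compound 2 (0.26 log units; within the scatter) lies within the scatter. Compound 3 `Cc1ccc(S(=O)(=O)OC[C@H]2O[C@@H](OCc3noc(-c4ccc([N+](=O)[O-])cc4)n3)[C@@H]3OC4(CCCC4)O[C@@H]32)cc1` differs from compound 2 by ((4-methylphenyl)sulfonyl)oxy in place of (1H-1,2,4-triazol-5-yl)sulfanyl on a saturated chain carbon bound to a saturated ring carbon. Going by the values given here, the only measured step at this place, from compound 1 to compound 2, stayed within the scatter, so for compound 3 in this assay no step beyond the scatter is expected, that is no change at the digits printed from compound 2 to compound 3 (within the scatter). Compound 3 is therefore estimated at 15000 nM, within 5000 nM to 45000 nM.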

Compound 3, concentration for 50% growth inhibition: > 100000 nM
Compound 3 was reported as a limit; the forecaster's own chance of this, stated with the estimate: 10%; at least 6.6-fold (0.82 log units) between middle value and limit.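

In this assay this place does respond to what it carries: ((4-methylphenyl)sulfonyl)oxy brings an at least 6.6-fold higher number from compound 2 to compound 3 (0.82 log units; beyond the scatter) and also an at least 3.7-fold higher number from compound 1 to compound 3 (0.56 log units; beyond the scatter), whereas the earlier exchange at this place stayed within the scatter. From the compounds shown here alone, compound 3 is held only as a limit, so the full size of both steps stays unknown: the limit of > 100000 nM in this assay, at which 1 of the 3 values shown sits.

Going by these compounds, whether an amine or a carboxylic acid at this place would stay with compound 1 and compound 2 or move as far as compound 3 remains open. Also open, on these data alone, is whether the sulfonyl part or the six-membered aromatic ring of the entering group carries the step.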